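Chloro Added to the Phenyl Ring, Measured Twice

The compounds below may be only part of what the source reports. "The series", "measured", "known", "first", "only" and "open" are said of these compounds alone.

Compound 1 `O=C(O)Cc1sc(Nc2ccccc2)nc1-c1ccc(F)cc1` and compound 2 `O=C(O)Cc1sc(Nc2ccc(Cl)cc2)nc1-c1ccc(F)cc1` share one core, while compound 3 `O=C(O)Cc1sc(Cc2ccc(Cl)cc2)nc1-c1ccccc1` is built on another; the difference between the two cores is not broken down here. Compound 4 `O=C(O)Cc1sc(Cc2ccc(Cl)cc2)nc1-c1ccc(Cl)cc1` has not yet been measured. In an in vitro assay on COS-7 cells for displacement of a labelled ligand from prostaglandin D2 receptor 2 (Homo sapiens) (on this read-out lower numbers stand for stronger inhibition and higher numbers for weaker inhibition), compound 1 gives 650 nM, compound 2 gives 960 nM, and compound 3 gives 88 nM, the lowest number of the three. The change from compound 1 to compound 2 is chloro in place of hydrogen on an aromatic carbon, and it brought a 1.5-fold higher number from compound 1 to compound 2 (0.17 log units; within the scatter). The same change is now made from compound 3 to compound 4: chloro in place of hydrogen on an aromatic carbon. Both changes sit on an aromatic carbon of a six-membered aromatic ring of carbon only, para to a large group, so the surroundings of the new chloro read alike in both pairs. The step expected from compound 3 to compound 4 is a 1.4-fold higher number from compound 3 to compound 4 (0.13 log units; within the scatter), because the earlier instance of this change gave a 1.5-fold higher number from compound 1 to compound 2 (0.17 log units; within the scatter). Compound 4 is therefore estimated to give 120 nM in this assay, with a likely range from 50 nM to 300 nM.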

Compound 4, half-maximal inhibitory concentration: 50 nM
Beside the measured number, compound 4's estimate is 2.4-fold (0.38 log units) above it; the range from low to high includes it.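

In this assay, turning phenyl into 4-chlorophenyl gave a 1.8-fold lower number from compound 3 to compound 4 (0.25 log units; within the scatter), so on this core the change again moved the number by no more than repeated measurements of one compound can do. Set side by side, the two instances can be treated as alike, with neither step nor the gap between them standing out from the noise: the same change on two cores in this assay, a 1.5-fold higher number (0.17 log units; within the scatter) from compound 1 to compound 2 and a 1.8-fold lower number (0.25 log units; within the scatter) from compound 3 to compound 4, 2.6-fold (0.41 log units) apart, within the scatter of two such steps. This suggests that, across these two pairs, chloro in place of hydrogen carries over from one core to the other without a measurable shift, but it does not show that the change has no effect at all, that any small effect is the same on both cores, or that the result would hold on a third core.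

The compounds shown leave open whether a methoxy group or a nitrile on the same aromatic carbon would behave as chloro does. They also leave open how a step of this kind would read on a core carrying an amide in place of the carboxylic acid.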